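The source may report more compounds than this note shows. Statements on the series, on what has been measured and on what is new or still open speak of the compounds shown alone.

Measured so far, in a functional assay on PC-3 cells (Homo sapiens) for cytotoxicity, read by MTT assay, with a stated time of 48 h; a lower number here means a stronger inhibitor, a higher number a weaker inhibitor:
- compound 1, `CCn1c(/C=C2/C(=O)Nc3ccc(F)cc32)nc2ccccc21`: > 50000 nM, a limit of the assay rather than a number
- compound 2, `Cn1c(/C=C2/C(=O)Nc3ccc(Cl)cc32)nc2ccccc21`: > 50000 nM, likewise a limit rather than a number

Going by the values given here, compound 2 thus stands at the edge of what this assay can report: no strength of inhibition was recorded for it, only that the value lies beyond the limit, and the same holds for the one other value shown, because of the limit of > 50000 nM in this assay, at which 2 of the 2 values shown sit. Compound 3, `CCn1c(/C=C2/C(=O)Nc3ccc(Cl)cc32)nc2ccccc21`, is not yet measured. It differs from compound 2 by methyl in place of hydrogen on a saturated chain carbon bound to an aromatic nitrogen. Among the compounds with values here, no step between two measured compounds is available to weigh this change. The step that the limit leaves unreadable from compound 2 to compound 3 is therefore expected to be none beyond the usual scatter, if any. Compound 3 is expected to give 80000 nM, within a range of 30000 nM to 200000 nM, most likely reported again as a limit.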

Compound 3, half-maximal inhibitory concentration: > 50000 nM
Compound 3: no number, only a limit; the forecaster's own chance of this, stated with the estimate: 80%; the middle value does not contradict the limit.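

In this assay compound 3 gives > 50000 nM, again a limit rather than a number. The steps linking compound 3 to compound 1 and compound 2 therefore cannot be read: the limit of > 50000 nM in this assay, at which 3 of the 3 values shown sit. On these data alone, whether swapping methyl for ethyl or fluoro for chloro changes the strength of inhibition remains open.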